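The source may hold more compounds than are shown below. What is called first, only, known or untested is meant among the compounds shown, and "the series" means these compounds.

Measured so far, in an assay on COS-7 cells for inhibition of patatin-like phospholipase domain-containing protein 2 (Mus musculus), tested at 200 uM; on this read-out lower numbers stand for less inhibition and higher numbers for more inhibition at the one concentration tested (going by the name of the read-out):
compound 1 `CCOC(=O)c1cccc(-c2ccc(OCC)cc2)c1` gives 87%
compound 2 `CCOC(=O)c1ccc(-c2ccc(OCC)cc2)s1` gives 81%
compound 3 `CCOC(=O)c1cccc(-c2ccc(OC)cc2)c1` gives 77%

Compound 3 stands at the bottom of these three numbers, but the gaps to compound 2 and to compound 1 both lie within the scatter, so the three cannot be ranked.

Compound 4 `CCOC(=O)c1cccc(-c2ccc(C)cc2)c1` is not yet measured. Its change from compound 3 is methyl in place of methoxy on an aromatic carbon. For the measured compounds named here, the only step measured on the same ring is a number 10 percentage points lower from compound 1 to compound 3 (within the scatter), which trimmed the alkoxy chain on that ring and stayed within the scatter. Removing the oxygen altogether is a larger change, but nothing measured points in either direction. The step of a number 5 percentage points lower from compound 3 to compound 4 (within the scatter) is therefore expected to stay within the scatter. For compound 4 the expected value is 72%, with a range from 55% to 88%.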

Compound 4, a percentage reported as inhibition, at one concentration (the size of the read-out at that concentration, not a potency): 63%
The estimate for compound 4 lay 9 percentage points above the measured number, within the range that was stated.
By their numbers in this assay, from the lowest: compound 4; then compounds 3, 2 and 1 (each within the scatter of the next).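

In this assay, methyl in place of methoxy on this aromatic carbon, para to a large group, gives a number 14 percentage points lower from compound 3 to compound 4 (beyond the scatter), and methyl in place of ethoxy gives a number 24 percentage points lower from compound 1 to compound 4 (beyond the scatter). For the compounds shown here, these are the first steps beyond the scatter at this position: trimming ethoxy to methoxy stayed within it, while replacing either alkoxy group with methyl did not. Nothing available explains this difference.

Open, on these data alone, is whether a propoxy chain, a hydroxyl or an amine here would read like the alkoxy groups or like methyl. Also open, as far as these compounds go, is whether the same change would give a comparable step on the core of compound 2.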